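This account rests on a few compounds, and the source may have more. Where it says the series, first, only, none or still open, it means among the compounds named here.

Measured so far in a functional assay on HCT-116 cells (Homo sapiens) for antiproliferative activity, read by MTT assay, with a stated time of 48 h; a lower number here means a stronger inhibitor, a higher number a weaker inhibitor:
- Compound 1 (`COc1cc(-c2nnc3c(OC4COC4)cc(-c4ccc5[nH]ccc5c4)cn23)cc(OC)c1OC`): 5370 nM
- Compound 2 (`COc1cc(-c2nnc3c(OC4CCC4)cc(-c4ccc5[nH]ccc5c4)cn23)cc(OC)c1OC`): 694 nM

Compound 2 has the lower of these two numbers. Compound 3 (`COc1cc(-c2nnc3c(OC4CC4)cc(-c4ccc5[nH]ccc5c4)cn23)cc(OC)c1OC`) is not yet measured. It differs from compound 2 as follows: cyclopropyl in place of cyclobutyl on an oxygen on an aromatic ring. In words, cyclopropyl replaces cyclobutyl on an oxygen on an aromatic ring. Among the measured compounds shown here, one measured step bears on this place: a 7.7-fold lower number from compound 1 to compound 2 (0.89 log units; beyond the scatter). That step exchanged oxetan-3-yl for cyclobutyl, so it offers only a loose guide to a swap between two rings of carbon only. A smaller change is expected here, probably towards a somewhat higher number. The expected step is a 1.4-fold higher number from compound 2 to compound 3 (0.16 log units; within the scatter). For compound 3 the estimated value is 1000 nM, with an expected range of 350 nM to 3000 nM.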

Compound 3, half-maximal inhibitory concentration: 275 nM
For compound 3 the middle estimate is 3.6-fold (0.56 log units) above the measured one; measured number outside the range, below it.
By their numbers in this assay, from the lowest: compound 3; then compound 2; then compound 1.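

In this assay, the ring on this oxygen matters even when it holds only carbon: cyclopropyl in place of cyclobutyl gives a 2.5-fold lower number from compound 2 to compound 3 (0.40 log units; beyond the scatter), so the smaller carbon ring gives the stronger inhibitor of these two. Replacing oxetan-3-yl with cyclopropyl gives a 20-fold lower number from compound 1 to compound 3 (1.29 log units; beyond the scatter), the widest gap among these compounds. No available measurement explains these differences.

An open chain such as ethyl or isopropyl on this oxygen remains untested among the compounds shown. So does a larger carbon ring such as cyclopentyl, or a ring carrying an amine.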